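A few compounds are considered here, and "the series" means these few. Any claim that something is new, unique, unknown or untested is made for them only; others in the source may bear on it.

Working notes on the series. Compound 1 `CC[C@@H]1/C=C(\C)C[C@H](C)C[C@H](OC)[C@H]2O[C@@](O)(C(=O)C(=O)N3CCCC[C@H]3C(=O)O[C@H](/C(C)=C/[C@@H]3CC[C@@H](O)[C@H](Oc4ccc(O)cc4)C3)[C@H](C)[C@@H](O)CC1=O)[C@H](C)C[C@@H]2OC` gives 0.9 nM in a functional assay on cells for inhibition, with Murine T-cell line (Mus musculus) as the target; on this read-out lower numbers stand for stronger inhibition and higher numbers for weaker inhibition. Among the compounds with values here, compound 3 `CC[C@@H]1/C=C(\C)C[C@H](C)C[C@H](OC)[C@H]2O[C@@](O)(C(=O)C(=O)N3CCCC[C@H]3C(=O)O[C@H](/C(C)=C/[C@@H]3CC[C@@H](O)[C@H](Oc4ccc(C)cc4)C3)[C@H](C)[C@@H](O)CC1=O)[C@H](C)C[C@@H]2OC` gives 2.6 nM, and the one-point step a 2.9-fold higher number from compound 1 to compound 3 (0.46 log units; beyond the scatter) is the only measured step within the set. Compound 2 `CC[C@@H]1/C=C(\C)C[C@H](C)C[C@H](OC)[C@H]2O[C@@](O)(C(=O)C(=O)N3CCCC[C@H]3C(=O)O[C@H](/C(C)=C/[C@@H]3CC[C@@H](Oc4ccc(C(F)(F)F)cc4)[C@H](OC)C3)[C@H](C)[C@@H](O)CC1=O)[C@H](C)C[C@@H]2OC` gives 35.8 nM, the highest of the three numbers; its gaps to compound 3 and to compound 1 both lie beyond the scatter, so compound 2 is the weakest inhibitor measured so far.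

Compound 4 `CC[C@@H]1/C=C(\C)C[C@H](C)C[C@H](OC)[C@H]2O[C@@](O)(C(=O)C(=O)N3CCCC[C@H]3C(=O)O[C@H](/C(C)=C/[C@@H]3CC[C@@H](Oc4ccc(N(C)C)cc4)[C@H](OC)C3)[C@H](C)[C@@H](O)CC1=O)[C@H](C)C[C@@H]2OC` differs from compound 2 in one place: dimethylamino in place of trifluoromethyl on an aromatic carbon. Within the data shown here, no measured step covers this exchange. The step from compound 1 to compound 3 concerns a different group on the same kind of aromatic carbon and a different core substitution, and it was modest, so it offers only a loose guide to the size of a single para change. The direction for compound 4 is therefore uncertain; a small step, possibly toward a lower number, is the expectation, given as a 1.8-fold lower number from compound 2 to compound 4 (0.25 log units; within the scatter). Compound 4 is estimated at 20 nM in this assay, with a range from 6 nM to 70 nM.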

Compound 4, half-maximal inhibitory concentration: 1.1 nM
Compound 4: the middle estimate sits 18-fold (1.26 log units) above what was measured, and the stated range ends above it.
By their numbers in this assay, from the lowest: compounds 1 and 4 (each within the scatter of the next); then compound 3; then compound 2.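

In this assay, within the data shown here, the exchange of trifluoromethyl for dimethylamino gives a 33-fold lower number from compound 2 to compound 4 (1.51 log units; beyond the scatter), so a single group on this aromatic carbon, para to a large group, can carry a large change, whereas the only earlier step on such a carbon, a 2.9-fold higher number from compound 1 to compound 3 (0.46 log units; beyond the scatter), was modest. The core shared by compound 2 and compound 4 therefore does not by itself hold the number high, and the weak result of compound 2 goes with trifluoromethyl on that core. Nothing available explains the size of this step.

Still open, from the compounds shown here alone, is whether the gain needs dimethylamino itself, or whether an unsubstituted amine, a methoxy group or a carboxylic acid on the same carbon would give a similar number. Going by these compounds, it is equally open whether dimethylamino would act in the same way on the core of compound 1.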